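The source may hold more compounds than are shown below. What is called first, only, known or untested is meant among the compounds shown, and "the series" means these compounds.

In an ADME assay on liver (Mus musculus) for metabolic stability, read by LC-MS, using microsomes and NADPH (on this read-out lower numbers stand for a less stable compound and higher numbers for a more stable compound), compound 1 (`CCN(Cc1ccc(OCCN2C(=O)CCC2=O)c(C)c1)C(CC(=O)O)c1ccc(Cl)cc1`) gives 88% and compound 2 (`Cc1cc(CN(CC2CC2)[C@@H](CC(=O)O)c2ccc(Cl)cc2)ccc1OCCN1C(=O)CCC1=O`) gives 87% so the two numbers shown for the series lie within the scatter of each other. Compound 3 (`Cc1cc(CN(CC2CCCC2)C(CC(=O)O)c2ccc(Cl)cc2)ccc1OCCN1C(=O)CCC1=O`) differs from compound 1 in one place: cyclopentyl in place of methyl on a saturated chain carbon bound to an amine nitrogen. Within the data shown here, no measured step sizes this change. A modest fall is expected in this assay with a number 10 percentage points lower from compound 1 to compound 3 (within the scatter) as the estimated step, close to the edge of the scatter. For compound 3 the expected value is 78% (estimated range 58% to 92%).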

Compound 3, percent of the compound remaining: 52%
Estimate against measurement, compound 3: 26 percentage points above; the whole stated range lies above it.
By their numbers in this assay, from the lowest: compound 3; then compounds 2 and 1 (each within the scatter of the next).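

The place on a saturated chain carbon bound to an amine nitrogen is sensitive in this assay, which shows a number 36 percentage points lower from compound 1 to compound 3 (beyond the scatter) for cyclopentyl in place of methyl. Among these compounds, compound 1 and compound 2 lay within the scatter of each other and gave no hint of a step this large. Nothing at hand bears on the reason for it.

Going by these compounds, whether the value falls gradually or abruptly as the group grows stays open. Cyclobutyl or tetrahydropyranyl at this place would bear on that question.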